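Swapping the oxime for a ketone on the fused ring

The source may hold more compounds than are shown below. What is called first, only, known or untested is meant among the compounds shown, and "the series" means these compounds.

Compound 1 `CCn1c(CNc2ccccc2)nnc1SCC(=O)Nc1ccc(C(=O)OC)cc1` gives 540 nM in an assay on isolated protein for inhibition of long-chain fatty acid transport protein 1 (Homo sapiens); on this read-out lower numbers stand for stronger inhibition and higher numbers for weaker inhibition. Going by these compounds, compound 2 `CCn1nnc(-c2ccc(NC(=O)CSc3nnc(CNc4ccccc4)n3CC)cc2)n1` reaches only the limit of this assay, > 1000 nM, so its number is unknown; the change an at least 1.8-fold higher number from compound 1 to compound 2 (0.26 log units; that floor lies within the scatter) therefore cannot be sized. Compound 3 `CC/C(=N/OC)c1ccc2oc(CSc3nnc(CNc4ccccc4)n3CC)nc2c1` likewise sits at the limit, > 1000 nM, so it stands among the weaker members of this small set and no firm number is known for it. Compound 4 `CCn1c(CNc2ccccc2)nnc1SCc1nc2cc(C(=O)C(C)C)ccc2o1` differs from compound 3 by a group of 5 heavy atoms (4 carbon, 1 oxygen; no ring) in place of a group of 6 heavy atoms (4 carbon, 1 nitrogen, 1 oxygen; no ring), on an aromatic carbon, on an aromatic carbon of the six-membered ring within the fused system of two rings. Going by the values given here, no measured step touches this position or this group, and the one measured step runs from a number into a limit, so it offers no guide. Starting from a limit, compound 4 is expected to stay weak, with an estimated step that the limit leaves unreadable from compound 3 to compound 4 and an estimated value of 1800 nM, plausibly between 500 nM and 6000 nM.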

Compound 4, half-maximal inhibitory concentration: 600 nM
For compound 4 the middle estimate is 3.0-fold (0.48 log units) above the measured one; the measured number falls inside the stated range.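

Placing isopropylcarbonyl on this aromatic carbon of the fused system gives a readable number in this assay, with an at least 1.6-fold lower number from compound 3 to compound 4 (0.22 log units; that floor lies within the scatter). Only the floor of that step is known, and it lies within the usual scatter. Its full size stays hidden because the value of compound 3 is a limit: the limit of > 1000 nM in this assay, at which 2 of the 4 values shown sit.

The compounds shown leave open how a carboxylic acid or an amine on this aromatic carbon would read. They also leave open whether a longer chain in place of the isopropyl part of the ketone would keep a measurable number.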